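From a hydroxyphenyl to a chlorophenyl group

The compounds below may be only part of what the source reports. "The series", "measured", "known", "first", "only" and "open" are said of these compounds alone.

Measured in a functional assay on SGC-7901 cells (Homo sapiens) for inhibition, read by MTT assay, with a stated time of 24 h; a higher number here means a weaker inhibitor, a lower number a stronger inhibitor:
- compound 1 `CC1(C)[C@H]2CC[C@]1(C)N(Cc1cn(-c3ccccc3C#N)nn1)C(=O)C2`: 260 nM
- compound 2 `CC1(C)[C@H]2CC[C@]1(C)N(Cc1cn(-c3cccc(O)c3)nn1)C(=O)C2`: 270 nM

In this assay, going by the values given here, compound 2 at 270 nM cannot be told apart from compound 1, the only other measured compound. Compound 3 `CC1(C)[C@H]2CC[C@]1(C)N(Cc1cn(-c3ccc(Cl)cc3)nn1)C(=O)C2` carries 4-chlorophenyl in place of 3-hydroxyphenyl on an aromatic nitrogen. Among the compounds with values here, the only measured step at this place, a 1.0-fold higher number from compound 1 to compound 2 (0.02 log units; within the scatter), lies within the scatter and shows no direction. Within the data shown here, no chlorophenyl compound has been measured yet, so no step beyond the scatter is expected. The estimated step is a 1.0-fold lower number from compound 2 to compound 3 (0.02 log units; within the scatter). Compound 3 is expected at 260 nM, with an estimated range of 90 nM to 750 nM.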

Compound 3, half-maximal inhibitory concentration: 410 nM
Compound 3: the middle estimate sits 1.6-fold (0.20 log units) below what was measured; measured number inside the range.
By their numbers in this assay, from the lowest: compounds 1, 2 and 3 (each within the scatter of the next).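

In this assay, the 4-chlorophenyl group gives a 1.5-fold higher number from compound 2 to compound 3 (0.18 log units; within the scatter) and a 1.6-fold higher number from compound 1 to compound 3 (0.20 log units; within the scatter), so both steps stay within the scatter. Compound 3 thus shows that a phenyl ring bearing chlorine, with 0 hydrogen-bond donors and 0 hydrogen-bond acceptors, can replace 3-hydroxyphenyl on this aromatic nitrogen without a step beyond the scatter. No available evidence bears on this result. The compounds shown leave open whether an amine or a carboxylic acid on the phenyl ring would give a step beyond the scatter. They also leave open what a saturated alkyl chain would do in place of the phenyl ring.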